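The compounds below may be only part of what the source reports. "The series", "measured", "known", "first", "only" and "open" are said of these compounds alone.

The measured compounds, with their values in an assay on HepG2 cells for activation of nuclear factor erythroid 2-related factor 2 (Homo sapiens), read by a luciferase reporter, with a stated time of 5 h; a lower number here means that less compound is needed, a higher number that more compound is needed for the effect:
Compound 1, `Fc1ccccc1/C=C/c1ccc(Cl)cc1`: 1600 nM.
Compound 2, `Fc1ccc(/C=C/c2ccccc2F)cc1F`: > 15000 nM, which is a limit of the assay and not a number.
Compound 3, `Fc1ccc(/C=C/c2ccccc2F)cc1`: 3600 nM.

Of the two numbers shown, compound 3 gives the highest, so more of it is needed than of compound 1. The nearest is compound 1, and the step of a 2.3-fold higher number from compound 1 to compound 3 (0.35 log units; beyond the scatter) goes with a fluoro in place of chloro on an aromatic carbon.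

Compound 4, `Fc1ccc(/C=C/c2ccc(F)cc2F)cc1`, has not yet been measured. Compared with compound 3 it differs in one place: fluoro in place of hydrogen on an aromatic carbon. For the measured compounds named here, one measured step bears on this kind of change, though in the opposite direction: an at least 4.1-fold lower number from compound 2 to compound 3 (0.61 log units; beyond the scatter). That step starts from compound 2, whose value is only a limit (the limit of > 15000 nM in this assay, at which 1 of the 3 values shown sits). Read forwards, adding a fluoro to an aromatic carbon raised the number by at least a modest amount. In compound 4 the added fluoro sits on the other ring of the shared core, so the step need not match in size, but an upward direction is expected. For compound 4 the expected step is a 2.2-fold higher number from compound 3 to compound 4 (0.35 log units; beyond the scatter). Compound 4 is therefore estimated at 8000 nM, with a range from 3000 nM to 20000 nM.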

Compound 4, half-maximal effective concentration: 900 nM
The estimate for compound 4 lay 8.9-fold (0.95 log units) above the measured number, outside the stated range (below it).
By their numbers in this assay, from the lowest: compounds 4 and 1 (each within the scatter of the next); then compound 3. At a limit, above all of these: compound 2.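

In this assay, a fluoro on an aromatic carbon, meta to a fluoro group and para to a group of 9 heavy atoms, brings a 4.0-fold lower number from compound 3 to compound 4 (0.60 log units; beyond the scatter), so adding this atom here lowers the number. For the compounds shown here, until now the only step of this kind pointed the other way, an at least 4.1-fold lower number from compound 2 to compound 3 (0.61 log units; beyond the scatter), with the extra fluoro on the other ring, so adding a fluoro has no single direction across these compounds, and compound 2 and compound 4 go against any such rule. Compound 2 gives > 15000 nM, which is a limit of the assay and not a number, so the size of that opposite effect stays unknown: the limit of > 15000 nM in this assay, at which 1 of the 4 values shown sits.

From the compounds shown here alone, whether a methoxy group or an amine at the new position would also lower the number stays open. The compounds shown also do not tell why the same change moves the number in opposite directions on the two rings.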